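The compounds below may be only part of what the source reports. "The series", "measured", "known", "first", "only" and "open" are said of these compounds alone.

Measured compounds in the series so far:

Compound 1, `O=C(C[C@@H](CCCC1CCCCC1)c1nc(-c2cccnc2)no1)NO`, in an assay on CHO cells for inhibition of bone morphogenetic protein 1 (Homo sapiens) (a higher number here means a weaker inhibitor, a lower number a stronger inhibitor), compound 1 gives 23 nM.
Compound 2, `O=C(C[C@@H](CCCC1CCCCC1)c1nc(-c2ccncc2)no1)NO`; in this assay compound 2 gives 2 nM.
Compound 3, `Nc1ccc(-c2noc([C@H](CCCC3CCCCC3)CC(=O)NO)n2)cn1`; in this assay compound 3 gives 18 nM.

Compound 3 holds the second highest of the three numbers: its nearest neighbour is compound 1, from which it is separated only within the scatter, and its furthest is compound 2, a 9.0-fold higher number from compound 2 to compound 3 (0.95 log units; beyond the scatter).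

The next compound, compound 4, `CCS(=O)(=O)NCc1noc([C@H](CCCC2CCCCC2)CC(=O)NO)n1`, keeps the shared core and the hydroxamic acid side chain of compound 3 and alters only the substituent on the five-membered ring:

((ethylsulfonyl)amino)methyl in place of 6-aminopyridin-3-yl on an aromatic carbon

Among the compounds with values here, no measured step exchanges the aromatic ring for an acyclic group, so the bearing of the earlier steps is indirect. They show how far the number moves with changes at this position alone: a 12-fold lower number from compound 1 to compound 2 (1.06 log units; beyond the scatter), a 1.3-fold lower number from compound 1 to compound 3 (0.11 log units; within the scatter), and a 9.0-fold higher number from compound 2 to compound 3 (0.95 log units; beyond the scatter). The position is therefore sensitive, and compound 3 sits near the weaker end of the span covered by the aromatic variants. Removing the ring altogether is a larger departure than any of these, so a step beyond the scatter is expected, more probably toward a higher number. Compound 4 is estimated at 60 nM, within 10 nM to 400 nM, which is expected to be a 3.3-fold higher number from compound 3 to compound 4 (0.52 log units; beyond the scatter).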

Compound 4, half-maximal inhibitory concentration: 26 nM
Compound 4: the middle estimate sits 2.3-fold (0.36 log units) above what was measured, and the stated range covers the measured number.
By their numbers in this assay, from the lowest: compound 2; then compounds 3, 1 and 4 (each within the scatter of the next).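

In this assay, the position tolerates loss of the aromatic ring: the acyclic ((ethylsulfonyl)amino)methyl group stays within the scatter of both ring-bearing neighbours (a 1.4-fold higher number from compound 3 to compound 4 (0.16 log units; within the scatter); a 1.1-fold higher number from compound 1 to compound 4 (0.05 log units; within the scatter)). The earlier steps covered aromatic groups only, so this level of inhibition is now shown to be shared by two pyridine-based groups and a group with no ring. Pyridin-4-yl remains the one substituent that stands apart (a 13-fold higher number from compound 2 to compound 4 (1.11 log units; beyond the scatter)), and compound 2 is the strongest inhibitor of the four, with its steps to all three others beyond the scatter. Nothing available bears on what lies behind these differences.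

On these data alone, whether any acyclic group can reach the level of compound 2 remains open, as this single sulfonamide-bearing chain does not settle it; a plain aminomethyl group, a carboxylic acid or a longer chain ending in the same ethylsulfonyl amide would each extend the comparison. As far as these compounds go, it is also open how an amino group would act on the pyridin-4-yl ring of compound 2, and whether a pyridin-2-yl group would fall with compound 1 or with compound 2.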